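The compounds below may be only part of what the source reports. "The series", "measured", "known", "first", "only" and "open" are said of these compounds alone.

Compound 1 `CSc1ncnc2c1c(-c1ccccc1)cn2[C@@H]1O[C@H](CO)[C@@H](O)[C@H]1O`: in a functional assay on HCT-116 cells (Homo sapiens), read by MTT assay, with a stated time of 72 h (a lower number here means a stronger inhibitor, a higher number a weaker inhibitor), compound 1 gives > 20000 nM, which is a limit of the assay rather than a number.
Compound 2 `Cc1ncnc2c1c(-c1cc3ccccc3o1)cn2[C@@H]1O[C@H](CO)[C@@H](O)[C@H]1O`: compound 2 gives > 20000 nM, again a limit.
Compound 3 `COc1nc(N)nc2c1c(-c1ccoc1)cn2[C@@H]1O[C@H](CO)[C@@H](O)[C@H]1O`: compound 3 gives > 20000 nM, also a limit.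

Compound 2 therefore stands level with both other compounds: all three share (the limit of > 20000 nM in this assay, at which 3 of the 3 values shown sit), and nothing separates them. Compound 4 `Cc1ncnc2c1c(-c1ccsc1)cn2[C@@H]1O[C@H](CO)[C@@H](O)[C@H]1O` has not yet been tested. It differs from compound 2 in one place (thiophen-3-yl in place of 1-benzofuran-2-yl on an aromatic carbon). For the measured compounds named here, no step between measured compounds exists, so there is no measured change to draw on. Compound 4 is expected to show no step beyond the scatter, a step that the limit leaves unreadable from compound 2 to compound 4, and most likely only a limit again. The estimate for compound 4 is 25000 nM, with a range from 8000 nM to 80000 nM.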

Compound 4, half-maximal inhibitory concentration: 1430 nM
Estimate against measurement, compound 4: 17-fold (1.24 log units) above; measured number below the stated range.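

This position on the shared core turns out to matter: in this assay, thiophen-3-yl in place of 1-benzofuran-2-yl gives an at least 13-fold lower number from compound 2 to compound 4 (1.14 log units; beyond the scatter). Compound 2 gives > 20000 nM, which is a limit, so this step is only a minimum. Compound 4 alone has a measured number, while the others stay at the ceiling: the limit of > 20000 nM in this assay, at which 3 of the 4 values shown sit.

From the compounds shown here alone, the change removes a six-membered ring and swaps oxygen for sulfur at once, so which of the two matters stays open. So does how 1-benzothiophen-2-yl or thiophen-2-yl would behave on this same carbon.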